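The source may report more compounds than this note shows. Statements on the series, on what has been measured and on what is new or still open speak of the compounds shown alone.

Series notes, chain-length step.

Compound 1 `CCCCCCCCCCCCCCOC(=O)CCC(=O)N1CCN(CCCOc2cc3c(Nc4ccc(F)c(Cl)c4)ncnc3cc2OC)CC1` gives, in a functional assay on A549 cells (Homo sapiens) for cytotoxicity, read by MTT assay, with a stated time of 24 h, tested at 10 uM (on this read-out lower numbers stand for a stronger effect and higher numbers for a weaker effect at the one concentration tested), 100%. Compound 2 `CCCCCCCCCCCCCCCCCCOC(=O)CCC(=O)N1CCN(CCCOc2cc3c(Nc4ccc(F)c(Cl)c4)ncnc3cc2OC)CC1` carries a longer ester chain and in this assay compound 2 gives 94.8%. The step of a number 5.2 percentage points lower from compound 1 to compound 2 (within the scatter) is within the scatter, so the two numbers cannot be told apart on this read-out; compound 2 stands beside compound 1 with no separation that the assay resolves.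

Compound 3 `CCCCCCCCCCCCCCCCCCCCOC(=O)CCC(=O)N1CCN(CCCOc2cc3c(Nc4ccc(F)c(Cl)c4)ncnc3cc2OC)CC1` extends the same chain once more: ethyl in place of hydrogen on a saturated chain carbon, ten or more bonds along the chain from an oxygen next to a carbonyl group. Within the data shown here, the only measured step that bears on this change is the chain extension from compound 1 to compound 2, which moved the read-out by a number 5.2 percentage points lower from compound 1 to compound 2 (within the scatter) and stayed within the scatter. A further extension of the same kind at the same place gives no ground to expect a step beyond the scatter in this assay in either direction. The step from compound 2 to compound 3 is therefore expected to be a number 1.8 percentage points lower from compound 2 to compound 3 (within the scatter). For compound 3 the expected read-out is 93%, with a range from 80% to 102%.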

Compound 3, a percentage reported as activity, at one concentration (the size of the read-out at that concentration, not a potency): 94%
For compound 3 the middle estimate is 1 percentage points below the measured one; the range from low to high includes it.
By their numbers in this assay, from the lowest: compounds 3, 2 and 1 (each within the scatter of the next).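

In this assay the ethyl in place of hydrogen on a saturated chain carbon, ten or more bonds along the chain from an oxygen next to a carbonyl group, gives a number 0.8 percentage points lower from compound 2 to compound 3 (within the scatter) and so joins the earlier butyl as a change that this read-out does not resolve. The new information lies in the full span: hexyl in place of hydrogen at the same place gives a number 6 percentage points lower from compound 1 to compound 3 (within the scatter) and thus shows that even the largest addition among these compounds stays within the scatter, which the butyl step alone could not show. Nothing measured here offers an explanation for this result.

Still open, from the compounds shown here alone, is whether any change at the ester end would separate from these three compounds, for instance a much shorter chain such as methyl, or a free carboxylic acid or an amine in place of the long ester. As the read-out comes from one concentration, it also leaves open whether the three compounds would differ at other concentrations or after another exposure time.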